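Ethyl homologue of a cyclic nucleotide: expected cytotoxicity

The source may hold more compounds than are shown below. What is called first, only, known or untested is meant among the compounds shown, and "the series" means these compounds.

Measured compounds:
compound 1 `CCCCCCCCc1cn([C@@H]2O[C@@H]3COP(=O)(O)O[C@H]3[C@H]2O)c(=O)nc1N`: > 200 ug/mL
compound 2 `Cc1cn([C@@H]2O[C@@H]3COP(=O)(O)O[C@H]3[C@H]2O)c(=O)nc1N`: > 200 ug/mL
compound 3 `CCCCCc1cn([C@@H]2O[C@@H]3CO[PH](O)(O)O[C@H]3[C@H]2O)c(=O)nc1N`: > 200 ug/mL

Compound 2 has been tested in a functional assay on L1210 cells (Mus musculus) for cytotoxicity; a lower number here means a stronger inhibitor, a higher number a weaker inhibitor. In this assay compound 2 gives > 200 ug/mL, which is a limit of the assay and not a number. Compound 1 likewise gives only the limit > 200 ug/mL. Compound 3 gives only the limit > 200 ug/mL. Among the compounds with values here, the single step between measured compounds, a step that the two limits leave unreadable from compound 1 to compound 2, therefore has no readable size, since every value shown sits at the same limit (the limit of > 200 ug/mL in this assay, at which 3 of the 3 values shown sit). Nothing about where compound 2 stands can be said beyond that limit.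

Compound 4 `CCc1cn([C@@H]2O[C@@H]3COP(=O)(O)O[C@H]3[C@H]2O)c(=O)nc1N` differs from compound 2 by methyl in place of hydrogen on a saturated chain carbon bound to an aromatic carbon. Within the data shown here, no measured step bears on this change in a readable way; the heptyl of compound 1 and the pentyl of compound 3 both leave the read-out at the limit, and the methyl of compound 2 does too. The expected step that the limit leaves unreadable from compound 2 to compound 4 is none that could be read beyond the scatter. Compound 4 is expected to give 300 ug/mL, between 150 ug/mL and 1000 ug/mL, most likely again reported only as a limit.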

Compound 4, concentration for 50% inhibition: > 200 ug/mL
Compound 4: only a limit was reported; the forecaster's own chance of this, stated with the estimate: 90%; the middle value does not contradict the limit.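

The steps from compound 4 to compound 1 and compound 2 cannot be read, so compound 4 adds no new step, because all the values remain limits of the assay and not numbers: the limit of > 200 ug/mL in this assay, at which 4 of the 4 values shown sit.

The compounds shown leave open whether any chain on the shared core affects cytotoxicity.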